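A few compounds are considered here, and "the series" means these few. Any claim that something is new, unique, unknown or untested is made for them only; others in the source may bear on it.

In a functional assay on HepG2 cells (Homo sapiens) for cytotoxicity, read by MTT assay, with a stated time of 48 h (a lower number here means a stronger inhibitor, a higher number a weaker inhibitor), compound 1 (`O=C(CSc1ccc([N+](=O)[O-])cc1)N1N=C(c2cc3ccccc3oc2=O)C[C@@H]1c1ccccc1C(F)(F)F`) gives 7700 nM and compound 2 (`O=C(CSc1ccc(Br)cc1)N1N=C(c2cc3ccccc3oc2=O)C[C@@H]1c1ccc(C(F)(F)F)cc1`) gives 12700 nM while compound 3 (`O=C(CSc1ncccn1)N1N=C(c2cc3ccccc3oc2=O)C[C@@H]1c1ccc(C(F)(F)F)cc1`) gives 4750 nM as its result. Compound 3 thus lies within the usual scatter of compound 1 and clearly lower than compound 2.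

Compound 4 (`O=C(CSc1ccc([N+](=O)[O-])cc1)N1N=C(c2cc3ccccc3oc2=O)C[C@@H]1c1ccc(C(F)(F)F)cc1`) has not been measured yet. It differs from compound 3 in one place, with 4-nitrophenyl in place of pyrimidin-2-yl on a sulfur as the whole change.

The closest evidence is a 2.7-fold lower number from compound 2 to compound 3 (0.43 log units; beyond the scatter) when pyrimidin-2-yl took the place of 4-bromophenyl on a sulfur. Among the measured compounds shown here, that step is modest, and it is the only measured step at this position. Compound 4 reverses its direction of change, going back to a six-membered aromatic ring of carbon only. Compound 1 also carries 4-nitrophenyl on a sulfur and gives 7700 nM even though it differs from compound 4 elsewhere.

For the measured compounds named here, a small rise in this assay is therefore expected, no larger than the one measured step. The estimate amounts to a 1.8-fold higher number from compound 3 to compound 4 (0.25 log units; within the scatter) as the expected change. Compound 4 is expected at 8500 nM within an estimated range of 3800 nM to 17000 nM for now.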

Compound 4, half-maximal inhibitory concentration: 7760 nM
The estimate for compound 4 lay 1.1-fold (0.04 log units) above the measured number; low and high end bracket the measured number.
By their numbers in this assay, from the lowest: compounds 3, 1, 4 and 2 (each within the scatter of the next, the first and the last beyond it).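

In this assay the new result gives a 1.6-fold higher number from compound 3 to compound 4 (0.21 log units; within the scatter) with 4-nitrophenyl in place of pyrimidin-2-yl on a sulfur, and a 1.6-fold lower number from compound 2 to compound 4 (0.21 log units; within the scatter) with nitro in place of bromo on an aromatic carbon. Compound 4 therefore cannot be told apart from either compound 3 or compound 2, even though those two stand apart beyond the scatter, so the separation seen earlier at this position does not extend to the nitro-bearing ring. Among the compounds shown here, the result also gives the first reading of the other varied place, a 1.0-fold higher number from compound 1 to compound 4 (0.00 log units; within the scatter) with 4-(trifluoromethyl)phenyl in place of 2-(trifluoromethyl)phenyl on a saturated ring carbon, and there the two numbers coincide.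

No measurement shown here accounts for any of these numbers. Still open, going by these compounds, is how a carboxylic acid or an amine would read in place of nitro on that aromatic carbon, and whether the match between compound 1 and compound 4 would hold with pyrimidin-2-yl on the sulfur.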